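Oxazole piperidine amides: rat microsomal half-life notes

This account rests on a few compounds, and the source may have more. Where it says the series, first, only, none or still open, it means among the compounds named here.

Measured so far:
compound 1 `Cc1oc(-c2ccccc2Cl)nc1CN1CCC(C(=O)NCCCN2C[C@H](C)C[C@H](C)C2)CC1` — an ADME assay on microsomes from liver (Rattus norvegicus) for metabolic stability, read by LC-MS, using NADPH, at 37 degrees C (a higher number here means that the compound lasts longer, a lower number that the compound disappears faster), 0.25 h
compound 2 `CCCN(CCC)CCNC(=O)C1CCN(Cc2nc(-c3ccccc3C)oc2C)CC1` — this assay > 0.5 h

Going by the values given here, compound 1 gives the only number among the values shown, 0.25 h in this assay. Compound 2 is reported only as a limit of the assay, > 0.5 h, which is the limit of > 0.5 h in this assay, at which 1 of the 2 values shown sits. Compound 3 `COc1ccc(-c2nc(CN3CCC(C(=O)NCCCN4C[C@H](C)C[C@H](C)C4)CC3)c(C)o2)cc1OC` has not yet been measured in this assay. It differs from compound 1 by 3,4-dimethoxyphenyl in place of 2-chlorophenyl on an aromatic carbon. Among the compounds with values here, no measured pair shares this change, so the direction of the step is uncertain; the expected step of a 1.1-fold lower number from compound 1 to compound 3 (0.06 log units; within the scatter) is taken as no more than the usual scatter. Compound 3 is therefore estimated at 0.22 h in this assay, in the range 0.08 h to 0.5 h.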

Compound 3, half-life: > 0.5 h
Compound 3: no number, only a limit; the forecaster's own chance of this, stated with the estimate: 10%; middle value at least 2.2-fold (0.35 log units) from the limit.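

In this assay, 3,4-dimethoxyphenyl in place of 2-chlorophenyl on this aromatic carbon gives an at least 2.0-fold higher number from compound 1 to compound 3 (0.30 log units; that floor lies within the scatter). This is the first step read at this position, and it sets only a floor, so the change is not shown to lower the number. Compound 3 stands at a limit and not at a number, which leaves the true size of the step unread: the limit of > 0.5 h in this assay, at which 2 of the 3 values shown sit.

Whether both methoxy groups are needed stays open, as a 4-methoxyphenyl or an unsubstituted phenyl at this position is not among the compounds shown. From the compounds shown here alone, how a pyridine ring would read in this assay also remains open.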